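The source may hold more compounds than are shown below. What is called first, only, known or untested is meant among the compounds shown, and "the series" means these compounds.

Measured so far:
- compound 1, `Clc1ccc(OCC2=NCCO2)cc1`: 60%
- compound 2, `Brc1ccccc1OCC1=NCCO1`: 90%
- compound 3, `Cc1ccccc1OCC1=NCCO1`: 60%

In a toxicity assay on the whole organism with Rattus norvegicus as the target, at a dose of 200 mg/kg by the oral route (on this read-out higher numbers stand for a stronger effect at the one dose given and lower numbers for a weaker effect), compound 3 gives 60%, level with compound 1 at the digits shown and, together with it, the lowest of the three numbers; the pair lies within the scatter of each other, so no order between them is claimed. Among the measured compounds shown here, the one change that separates compound 3 from compound 2 is a number 30 percentage points lower from compound 2 to compound 3 (beyond the scatter).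

Compound 4, `Clc1ccccc1OCC1=NCCO1`, is the next member. Its difference from compound 3 is chloro in place of methyl on an aromatic carbon.

For the measured compounds named here, the only measured step that bears on this change is the one from compound 2 to compound 3, where methyl in place of bromo lowered the number beyond the scatter. Compound 4 reverses the direction of that step, but with chloro entering rather than bromo returning, and the series holds no direct bromo-to-chloro comparison at this place on the ring. A rise from compound 3 to compound 4 is therefore expected, smaller than the step from compound 2 to compound 3, and the expected step is a number 15 percentage points higher from compound 3 to compound 4 (beyond the scatter). For compound 4 the estimate in this assay is 75%, with a range from 55% to 95%.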

Compound 4, a percentage reported as activity, at one dose (the size of the read-out at that dose, not a potency): 40%
Estimate against measurement, compound 4: 35 percentage points above; the whole stated range lies above it.
By their numbers in this assay, from the lowest: compound 4; then compounds 1 and 3 (each within the scatter of the next); then compound 2.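

In this assay, chloro in place of methyl on this aromatic carbon gives a number 20 percentage points lower from compound 3 to compound 4 (beyond the scatter) at this place, so the change does not undo the earlier step from bromo to methyl. Chloro in place of bromo gives a number 50 percentage points lower from compound 2 to compound 4 (beyond the scatter) here, which puts the two halogen-bearing compounds at opposite ends of compounds 2, 3 and 4, with the methyl compound lying between them. The read-out at this place therefore depends on which halogen is present, and nothing at hand explains the gap between chloro and bromo.

The compounds shown leave open where fluoro, iodo, methoxy or an amine at this place would fall relative to these three groups. They also leave open whether the gap between chloro and bromo holds at other places on the ring.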